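This account rests on a few compounds, and the source may have more. Where it says the series, first, only, none or still open, it means among the compounds named here.

Measured so far in a functional assay on T47D cells (Homo sapiens) for antiproliferative activity, read by MTT assay, with a stated time of 48 h; on this read-out higher numbers stand for weaker inhibition and lower numbers for stronger inhibition: compound 1 `COc1cc(/C=N/c2c(C#N)ncn2-c2ccc(F)cc2)ccc1O` gives 20100 nM; compound 2 `N#Cc1ncn(-c2ccc(F)cc2)c1/N=C/c1ccc(O)cc1` gives 20400 nM; compound 3 `COc1ccc(/C=N/c2c(C#N)ncn2Cc2ccc(F)cc2)cc1OC` gives 8200 nM.

Compounds 1 and 2 share a core and differ by methoxy in place of hydrogen on an aromatic carbon, a change that made a 1.0-fold lower number from compound 2 to compound 1 (0.01 log units; within the scatter). Compound 3 carries a different core; the difference between the two cores is not broken down here, and its number in this assay stands apart from those of compounds 1 and 2 as set out above.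

Compound 4 `COc1ccc(/C=N/c2c(C#N)ncn2Cc2ccc(F)cc2)c(OC)c1OC` is not yet measured. It differs from compound 3 by methoxy in place of hydrogen on an aromatic carbon. Among the compounds with values here, this is the same kind of change as the one from compound 2 to compound 1, though its surroundings differ: here the new group sits ortho to a large group, ortho to a methoxy group and meta to a methoxy group, whereas in compound 1 it sits ortho to a hydroxy group and meta to a large group. Because that earlier step was a 1.0-fold lower number from compound 2 to compound 1 (0.01 log units; within the scatter), the step from compound 3 to compound 4 in this assay is expected to be about a 1.1-fold higher number from compound 3 to compound 4 (0.04 log units; within the scatter). Compound 4 is therefore estimated at 9000 nM, most likely between 4000 nM and 22000 nM.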

Compound 4, half-maximal inhibitory concentration: > 25000 nM
Compound 4 ended at the assay's limit; the forecaster's own chance of this, stated with the estimate: 10%; at least 2.7-fold (0.44 log units) between middle value and limit.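

Methoxy in place of hydrogen on an aromatic carbon gave an at least 3.0-fold higher number from compound 3 to compound 4 (0.48 log units; beyond the scatter) in this assay, and the effect of this change did not carry over from one core to the other: the same change on two cores in this assay, a 1.0-fold lower number (0.01 log units; within the scatter) from compound 2 to compound 1 and an at least 3.0-fold higher number (0.48 log units; beyond the scatter) from compound 3 to compound 4, at least 3.0-fold (0.49 log units) apart, beyond the scatter of two such steps. On these data alone, compound 4 stands at a limit of the assay and not at a number, so the full size of its step stays unknown: the limit of > 25000 nM in this assay, at which 1 of the 4 values shown sits. The two steps differ in the core and also in the surroundings of the new group, and the data do not show which of these sets them apart.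

The compounds shown leave open how the same crowded arrangement of methoxy groups would read on the core of compound 1. They also leave open how an amine or a chloro group would read in place of the new methoxy on the core of compound 3.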